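The source may report more compounds than this note shows. Statements on the series, on what has been measured and on what is new or still open speak of the compounds shown alone.

Of the compounds shown here, three have been measured in a functional assay for antagonist activity at Alpha-1A adrenergic receptor (Oryctolagus cuniculus); on this read-out higher numbers stand for weaker binding and lower numbers for tighter binding. Compound 1 `COc1ccccc1N1CCN(CCCNc2cncnc2C(=O)N(C)C)CC1` gives 3.98 nM, compound 2 `COc1ccccc1N1CCN(CCCSc2ccccc2C(=O)N(C)C)CC1` gives 2 nM, and compound 3 `CCOc1ccccc1N1CCN(CCCNc2ncccc2C(=O)N(C)C)CC1` gives 0.501 nM, the lowest of the three numbers; its gap to compound 2 and its larger gap to compound 1 both lie beyond the usual scatter. Compound 4 `CCCc1ccccc1N1CCN(CCCNc2ncccc2C(=O)N(C)C)CC1` has not yet been measured in this assay. It differs from compound 3 in one place: propyl in place of ethoxy on an aromatic carbon. Among the compounds with values here, no measured pair shows this change, so its effect is an expectation only. The loss of the single hydrogen-bond acceptor is expected to cost some binding, giving a step of a 3.0-fold higher number from compound 3 to compound 4 (0.48 log units; beyond the scatter) that is modest but beyond the scatter. Compound 4 is therefore expected to give about 1.5 nM, within a range from 0.4 nM to 6 nM.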

Compound 4, dissociation constant: 0.2 nM
The estimate for compound 4 lay 7.5-fold (0.88 log units) above the measured number; the whole stated range lies above it.
By their numbers in this assay, from the lowest: compound 4; then compound 3; then compounds 2 and 1 (each within the scatter of the next).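

In this assay, propyl in place of ethoxy on this aromatic carbon gives a 2.5-fold lower number from compound 3 to compound 4 (0.40 log units; beyond the scatter) and so shows that tight binding here does not depend on the hydrogen-bond acceptor in ethoxy. An all-carbon chain of the same heavy-atom count is at least as good at this position, at least for this pair. Nothing available explains the gain. Whether a butyl chain or an amine on this carbon would bind as tightly remains open, as does whether propyl would have the same effect on the other cores shown.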